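A few compounds are considered here, and "the series" means these few. Any claim that something is new, unique, unknown or untested is made for them only; others in the source may bear on it.

Measured in an assay for inhibition of Nicotinamide phosphoribosyltransferase (Mus musculus), read by fluorescence, with a stated time of 1 h, in the presence of a further agent that is not named here; on this read-out higher numbers stand for weaker inhibition and lower numbers for stronger inhibition:

compound 1, `O=C(NCCCCCCCn1cc(-c2cccnc2)nn1)c1ccccc1-n1ccnn1`, gives 3.4 nM
compound 2, `CN(C)Cc1cn(-c2ccccc2C(=O)NCCCCCCCn2cc(-c3cccnc3)nn2)nn1`, gives 42.4 nM
compound 3, `O=C(NCCCCCCCn1cc(-c2cccnc2)nn1)c1ccccc1-n1cc(CN2CCCC2)nn1`, gives 25.4 nM

Compound 3 holds the second highest of the three numbers. Its nearest neighbour is compound 2, and the step of a 1.7-fold lower number from compound 2 to compound 3 (0.22 log units; within the scatter) lies within the scatter; the gap to compound 1, a 7.5-fold higher number from compound 1 to compound 3 (0.87 log units; beyond the scatter), is the one that stands out.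

Compound 4 is `CN1CCN(Cc2cn(-c3ccccc3C(=O)NCCCCCCCn3cc(-c4cccnc4)nn3)nn2)CC1`. The change from compound 3 is 4-methylpiperazin-1-yl in place of pyrrolidin-1-yl on a saturated chain carbon bound to an aromatic carbon.

Two kinds of step bear on this. Putting an aminomethyl group onto the shared core cost potency: a 12-fold higher number from compound 1 to compound 2 (1.10 log units; beyond the scatter) and a 7.5-fold higher number from compound 1 to compound 3 (0.87 log units; beyond the scatter). Swapping one amine for another on that same chain carbon, however, did not: a 1.7-fold lower number from compound 2 to compound 3 (0.22 log units; within the scatter). The step to compound 4 is a swap of the second kind, so in this assay the expected step of a 1.3-fold higher number from compound 3 to compound 4 (0.10 log units; within the scatter) is small, not beyond the scatter, with the number more likely to drift up than down given the larger ring entering.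

Compound 4 is therefore estimated at 32 nM, within a range of 12 nM to 85 nM.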

Compound 4, half-maximal inhibitory concentration: 13.6 nM
Beside the measured number, compound 4's estimate is 2.4-fold (0.37 log units) above it; the measured number falls inside the stated range.
By their numbers in this assay, from the lowest: compound 1; then compounds 4, 3 and 2 (each within the scatter of the next, the first and the last beyond it).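

In this assay, among these compounds, the (4-methylpiperazin-1-yl)methyl group shows that the choice of amine on this saturated chain carbon can matter: a 1.9-fold lower number from compound 3 to compound 4 (0.27 log units; within the scatter) stays within the scatter, yet a 3.1-fold lower number from compound 2 to compound 4 (0.49 log units; beyond the scatter) goes beyond it, the first amine swap here to do so. Even so, this group does not match plain hydrogen on the aromatic carbon, since a 4.0-fold higher number from compound 1 to compound 4 (0.60 log units; beyond the scatter) is also beyond the scatter, and so all three aminomethyl groups shown carry a cost against compound 1. No measurement offered here explains these differences.

The compounds shown leave open whether the second ring nitrogen of the 4-methylpiperazin-1-yl group matters, which a morpholin-4-yl or piperidin-1-yl group on the same chain carbon could test. Also open, on these data alone, is whether a carboxylic acid in place of the amine would narrow the gap to compound 1.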